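A few compounds are considered here, and "the series" means these few. Any claim that something is new, unique, unknown or untested is made for them only; others in the source may bear on it.

Compound 1, `O=C1NC[C@@H](c2c[nH]c3ccccc23)N[C@H]1c1c[nH]c2ccccc12`: in an ADME assay on A549 cells (Homo sapiens) for cytotoxicity (on this read-out higher numbers stand for an effect only at larger amounts of compound and lower numbers for an effect already at smaller amounts), compound 1 gives > 10 ug/mL, which is a limit of the assay rather than a number.
Compound 2, `O=C1NC[C@@H](c2c[nH]c3cc(Br)ccc23)N[C@H]1c1c[nH]c2ccccc12`: in this assay compound 2 gives 4.2 ug/mL.

Compound 1 thus stands only at a limit, and one of the two values sits there (the limit of > 10 ug/mL in this assay, at which 1 of the 2 values shown sits). Compound 3, `O=C1NC[C@@H](c2c[nH]c3ccccc23)N[C@H]1c1c[nH]c2cc(Br)ccc12`, differs from compound 1 by bromo in place of hydrogen on an aromatic carbon. Among the measured compounds shown here, the one measured step that bears on this, the same kind of change at another place on the shared core, is an at least 2.3-fold lower number from compound 1 to compound 2 (0.37 log units; beyond the scatter). A step of comparable size and direction is therefore expected, an at least 2.0-fold lower number from compound 1 to compound 3 (0.30 log units; that floor lies within the scatter), so for compound 3 the estimate is 5 ug/mL, between 2 ug/mL and 12 ug/mL.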

Compound 3, concentration for half-maximal effect: 9.67 ug/mL
For compound 3 the middle estimate is 1.9-fold (0.29 log units) below the measured one, and the stated range covers the measured number.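

In this assay, bromo at this place gives compound 3 a measured number rather than a limit, yet the step is only an at least 1.0-fold lower number from compound 1 to compound 3 (0.01 log units; that floor lies within the scatter). Bromo in place of hydrogen therefore does not give a step beyond the scatter here, unlike the floor printed for the same change at the other place on the shared core. On these data alone, the true size of the step stays unknown, and it can be read only as a floor: the limit of > 10 ug/mL in this assay, at which 1 of the 3 values shown sits. The compounds shown leave open how chloro or an amine at this place would read in this assay.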